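Testing the mirror image of compound 2

The source may report more compounds than this note shows. Statements on the series, on what has been measured and on what is new or still open speak of the compounds shown alone.

In a functional assay on HCT-116 cells (Homo sapiens) for inhibition, read by MTT assay, with a stated time of 72 h (on this read-out lower numbers stand for stronger inhibition and higher numbers for weaker inhibition), compound 1 `CC1=NN(c2ccccc2)C(=O)[C@]12C(=O)C=CC[C@H]2c1ccccc1[N+](=O)[O-]` gives 11200 nM and compound 2 `CC1=NN(c2ccccc2)C(=O)[C@]12C(=O)C=CC[C@H]2c1cccc(C)c1` gives 9580 nM. These two numbers lie within the usual scatter of each other, so compound 2 cannot be separated from compound 1 on this evidence.

The next case is compound 3 `CC1=NN(c2ccccc2)C(=O)[C@@]12C(=O)C=CC[C@@H]2c1cccc(C)c1`. The change here is the two compounds have the same atoms and bonds and differ only in configuration as drawn: 2 of 2 stereo elements differ (all stereocentres are inverted: mirror images); a stereocentre at a saturated ring carbon is drawn S in compound 2 and R in compound 3; a stereocentre at a saturated ring carbon is drawn S in compound 2 and R in compound 3. The two compounds therefore have the same atoms and bonds, and only their configuration as drawn differs.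

For the measured compounds named here, only one measured step exists, a 1.2-fold lower number from compound 1 to compound 2 (0.07 log units; within the scatter). It is small, but it swaps one group and does not invert any stereocentre, so it bears on this change only indirectly. Going by the values given here, no measured pair tests a change of configuration, and the data give no direction for one. Going by these compounds, the best anchor is compound 2 at 9580 nM, with a wide margin for what remains unknown. The expected result in this assay is therefore a 1.0-fold higher number from compound 2 to compound 3 (0.02 log units; within the scatter), with no expected shift beyond the scatter. For compound 3 the estimated value is 10000 nM, with an expected range of 3500 nM to 28000 nM.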

Compound 3, half-maximal inhibitory concentration: 3800 nM
The estimate for compound 3 lay 2.6-fold (0.42 log units) above the measured number, and the stated range covers the measured number.
By their numbers in this assay, from the lowest: compound 3; then compounds 2 and 1 (each within the scatter of the next).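

Inverting both stereocentres gives the first change in this set that lies beyond the scatter: in this assay there is a 2.5-fold lower number from compound 2 to compound 3 (0.40 log units; beyond the scatter), a modest step, whereas swapping the aryl group gave only a 1.2-fold lower number from compound 1 to compound 2 (0.07 log units; within the scatter). The shift can be assigned to configuration alone, because nothing else separates this pair: the fact that compounds 2 and 3 differ only in the configuration as drawn. The earlier compounds shown here, which share one drawn configuration, could not show this; compound 3 shows that, for this 3-methylphenyl compound, the result depends on which mirror image is tested, even though the atoms and bonds stay the same.

Both stereocentres change together here, so the compounds shown leave open whether one of them alone accounts for the step, and whether the mirror image of compound 1 would move in the same direction. They also leave open how the configuration drawn in compound 3 would behave with a different group on the phenyl ring, such as an amine or a carboxylic acid in place of the methyl of the 3-methylphenyl group.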